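The compounds below may be only part of what the source reports. "The series", "measured", "known", "first", "only" and "open" are said of these compounds alone.

In a functional assay on HepG2 cells (Homo sapiens) for antiproliferative activity, read by MTT assay, with a stated time of 72 h (on this read-out higher numbers stand for weaker inhibition and lower numbers for stronger inhibition), compound 1 `O=C(N/N=C/c1ccccc1)Nc1ccc(Oc2ccnc3[nH]ccc23)c(F)c1` gives 640 nM and compound 2 `CN(C)CCn1cccc1/C=N/NC(=O)Nc1ccc(Oc2ccnc3[nH]ccc23)c(F)c1` gives 8980 nM, the higher of the two numbers. Compound 3 `O=C(N/N=C/c1cccn1CCCN1CCCC1)Nc1ccc(Oc2ccnc3[nH]ccc23)c(F)c1` is next, with the change ((pyrrolidin-1-yl)methyl in place of dimethylamino on a saturated chain carbon, two bonds along the chain from an aromatic nitrogen). In words, this is (pyrrolidin-1-yl)methyl in place of dimethylamino on a saturated chain carbon, two bonds along the chain from an aromatic nitrogen. Among the measured compounds shown here, only one measured step bears on this, and only indirectly: a 14-fold higher number from compound 1 to compound 2 (1.15 log units; beyond the scatter). For the measured compounds named here, that large step replaced phenyl with the whole 1-(2-(dimethylamino)ethyl)-1H-pyrrol-2-yl group, and no measured step isolates the amine or the chain length. The present change is confined to the chain, so no step beyond the scatter is expected in this assay. The expected step is a 1.3-fold lower number from compound 2 to compound 3 (0.11 log units; within the scatter). For compound 3 the estimated value is 7000 nM, with an expected range of 2500 nM to 20000 nM.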

Compound 3, half-maximal inhibitory concentration: 3500 nM
Estimate against measurement, compound 3: 2.0-fold (0.30 log units) above; low and high end bracket the measured number.
By their numbers in this assay, from the lowest: compound 1; then compound 3; then compound 2.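

In this assay the change from 2-(dimethylamino)ethyl to 3-(pyrrolidin-1-yl)propyl gives a 2.6-fold lower number from compound 2 to compound 3 (0.41 log units; beyond the scatter) and so shows that the number moves beyond the scatter with the chain and its amine alone, which the earlier step from phenyl, replacing the whole group, could not show. The step is modest: compound 3 at 3500 nM still stands above compound 1 at 640 nM on this read-out, so the gap to the phenyl compound narrows but does not close. No evidence on hand accounts for this step.

Chain length and the amine change together here, so their separate shares remain open. A 3-(dimethylamino)propyl or a 2-(pyrrolidin-1-yl)ethyl chain would separate them, and a morpholine in place of the pyrrolidine would test the amine further.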